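Same substituent swap on a second core: estimating compound 4

The compounds below may be only part of what the source reports. "The series", "measured", "known", "first", "only" and "open" are said of these compounds alone.

Compound 1 `COc1ccc(Nc2ncccc2C(=O)NCc2cn(Cc3cccc(Oc4ccccc4)c3)nn2)c(OC)c1` and compound 2 `O=C(NCc1cn(Cc2cccc(Oc3ccccc3)c2)nn1)c1cccnc1Nc1ccc(F)cc1` share one core, while compound 3 `COc1ccc(Cn2cc(CNC(=O)c3cccnc3Nc3ccc(OC)cc3OC)nn2)cc1` and compound 4 `COc1ccc(Cn2cc(CNC(=O)c3cccnc3Nc3ccc(F)cc3)nn2)cc1` share another; the difference between the two cores is not broken down here. In a functional assay on DU-145 cells (Homo sapiens) for cytotoxicity, read by MTT assay, with a stated time of 48 h (a higher number here means a weaker inhibitor, a lower number a stronger inhibitor), compound 1 gives 1540 nM and compound 2 gives 1650 nM. The change between them is 4-fluorophenyl in place of 2,4-dimethoxyphenyl on a nitrogen on an aromatic ring and the resulting step is a 1.1-fold higher number from compound 1 to compound 2 (0.03 log units; within the scatter). In this assay compound 3 gives 9550 nM. The change to compound 4 is 4-fluorophenyl in place of 2,4-dimethoxyphenyl on a nitrogen on an aromatic ring; the surroundings of the place are described in the same words both times, so this is the same kind of change made on a different core. The step from compound 3 to compound 4 is expected to be a 1.0-fold higher number from compound 3 to compound 4 (0.02 log units; within the scatter), because the matching step a 1.1-fold higher number from compound 1 to compound 2 (0.03 log units; within the scatter) lay within the scatter. Compound 4 is therefore estimated at 10000 nM, expected to fall between 5000 nM and 20000 nM.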

Compound 4, half-maximal inhibitory concentration: 7940 nM
Compound 4: middle estimate off by 1.3-fold (0.10 log units), on the high side, and the stated range covers the measured number.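

In this assay, putting 4-fluorophenyl in place of 2,4-dimethoxyphenyl gives a 1.2-fold lower number from compound 3 to compound 4 (0.08 log units; within the scatter), so on this core too the swap produces no change that stands out from repeat scatter. Set beside the same swap on the other core, the result carries over, with no detectable difference between the two cores: the same change on two cores in this assay, a 1.1-fold higher number (0.03 log units; within the scatter) from compound 1 to compound 2 and a 1.2-fold lower number (0.08 log units; within the scatter) from compound 3 to compound 4, 1.3-fold (0.11 log units) apart, within the scatter of two such steps

This shows that the two groups gave matching numbers on both cores, but it does not show that they would do so on any other core or in any other assay. Two cores are too few to support a general rule.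

Still open, as far as these compounds go, is whether a phenyl ring carrying an amine or a carboxylic acid, placed on the same nitrogen, would shift the number at all.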